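A few compounds are considered here, and "the series" means these few. Any claim that something is new, unique, unknown or untested is made for them only; others in the source may bear on it.

Among the measured compounds shown here, in a functional assay on a cell-free system (plasma, Homo sapiens) for inhibition, with Plasma (Rattus norvegicus) as the target (on this read-out higher numbers stand for weaker inhibition and lower numbers for stronger inhibition), compound 1 (`COCOc1ccc2c(N3CCNCC3)cc(=O)oc2c1C`) gives 3500 nM and compound 2 (`CCOCOc1ccc2c(N3CCNCC3)cc(=O)oc2c1C`) gives 1900 nM, so compound 2 stands within the scatter of the only other measured compound. Compound 3 (`CSCCOc1ccc2c(N3CCNCC3)cc(=O)oc2c1C`) has (methylsulfanyl)methyl in place of ethoxy on a saturated chain carbon bound to an oxygen on an aromatic ring. For the measured compounds named here, the one measured step on this chain, a 1.8-fold lower number from compound 1 to compound 2 (0.27 log units; within the scatter), stays within the scatter, and no measured compound carries (methylsulfanyl)methyl. No shift beyond the scatter is expected, and the expected change is a 1.1-fold higher number from compound 2 to compound 3 (0.02 log units; within the scatter). Compound 3 is estimated at 2000 nM, with an expected range of 700 nM to 6000 nM.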

Compound 3, half-maximal inhibitory concentration: 1500 nM
Compound 3: the middle estimate sits 1.3-fold (0.12 log units) above what was measured; measured number inside the range.
By their numbers in this assay, from the lowest: compounds 3, 2 and 1 (each within the scatter of the next, the first and the last beyond it).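

In this assay, (methylsulfanyl)methyl in place of ethoxy on a saturated chain carbon bound to an oxygen on an aromatic ring gives a 1.3-fold lower number from compound 2 to compound 3 (0.10 log units; within the scatter), so a sulfur can stand in this chain without a shift beyond the scatter. Among the compounds shown here, with methoxy as the group replaced, the step reads a 2.3-fold lower number from compound 1 to compound 3 (0.37 log units; beyond the scatter), the first modest step to clear the scatter. No supporting data bear on this change. On these data alone, whether an amine, a carboxylic acid or a longer chain at this place would hold this level stays open.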